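The source may report more compounds than this note shows. Statements on the series, on what has been measured and on what is new or still open speak of the compounds shown alone.

Working notes on the series. Compound 1 `CC(O)c1cn(CCNc2nonc2/C(=N/O)Nc2ccc(F)c(Br)c2)nn1` gives 53 nM in an assay on isolated protein for inhibition of Indoleamine 2,3-dioxygenase 1 (Homo sapiens); on this read-out lower numbers stand for stronger inhibition and higher numbers for weaker inhibition. Compound 2 `CCC(C)(O)c1cn(CCNc2nonc2/C(=N/O)Nc2ccc(F)c(Br)c2)nn1` gives 53 nM in this assay, and compound 3 `CC(C)CC(C)(O)c1cn(CCNc2nonc2/C(=N/O)Nc2ccc(F)c(Br)c2)nn1` gives 51 nM in this assay. Compound 1 is level with compound 2, the pair together the highest of the three numbers, and compound 3 sits within the scatter of both. The steps of no change at the digits printed from compound 1 to compound 2 (within the scatter), a 1.0-fold lower number from compound 1 to compound 3 (0.02 log units; within the scatter) and a 1.0-fold lower number from compound 2 to compound 3 (0.02 log units; within the scatter) show that enlarging the saturated chain carbon bound to the aromatic carbon leaves the read-out flat. Compound 4 `CC(C)(OCCO)c1cn(CCNc2nonc2/C(=N/O)Nc2ccc(F)c(Br)c2)nn1` carries 1-(2-hydroxyethoxy)-1-methylethyl in place of 1-hydroxyethyl on an aromatic carbon. The measured steps bear on the added carbons; none covers moving the hydroxyl onto the ethoxy chain. Compound 4 is therefore expected to give 60 nM in this assay, range 25 nM to 150 nM. This estimate means a 1.1-fold higher number from compound 1 to compound 4 (0.05 log units; within the scatter), expected to stay within the scatter.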

Compound 4, half-maximal inhibitory concentration: 176 nM
Compound 4: middle estimate off by 2.9-fold (0.47 log units), on the low side; measured number outside the range, above it.
By their numbers in this assay, from the lowest: compounds 3, 1 and 2 (each within the scatter of the next); then compound 4.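

In this assay this position does not tolerate every change, although the added carbons of compounds 2 and 3 left the number flat: 1-(2-hydroxyethoxy)-1-methylethyl in place of 1-hydroxyethyl gives a 3.3-fold higher number from compound 1 to compound 4 (0.52 log units; beyond the scatter) and stands as the one clear shift in the series. The same group gives a 3.3-fold higher number from compound 2 to compound 4 (0.52 log units; beyond the scatter) and also a 3.5-fold higher number from compound 3 to compound 4 (0.54 log units; beyond the scatter) against the other two hydroxyl-bearing groups. Nothing available accounts for this rise.

Going by these compounds, it remains open whether the rise follows the ether oxygen or the more distant hydroxyl. A 1-methoxy-1-methylethyl group, or an amine at the chain end, would help separate the two.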